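From Compound 3 to Compound 4: An Expected Weaker Effect

This account rests on a few compounds, and the source may have more. Where it says the series, first, only, none or still open, it means among the compounds named here.

Measured so far in a functional assay on NCI-H226 cells (Homo sapiens) for inhibition, read by sulforhodamine B assay, with a stated time of 48 h, tested at 10 uM; a higher number here means a weaker effect of the compound at the concentration tested, a lower number a stronger effect:
- compound 1 `COc1cc(Cl)cc(-c2nn(-c3cccc(NC(=O)c4ccc(Cl)c(Cl)c4)c3)cc2-c2ccncc2)c1` gives 66.3%
- compound 2 `COc1cc(Cl)cc(-c2nn(-c3cccc(NC(=O)Nc4ccc(Cl)c(C(F)(F)F)c4)c3)cc2-c2ccncc2)c1` gives -2.82%
- compound 3 `COc1cc(Cl)cc(-c2nn(-c3cccc(NC(=O)Nc4cccc(C(F)(F)F)c4)c3)cc2-c2ccncc2)c1` gives 3.94%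

Compound 3 stands second highest of the three numbers. Its nearest neighbour is compound 2, the gap being a number 6.8 percentage points higher from compound 2 to compound 3 (within the scatter), which is within the scatter. Compound 1 lies far off: a number 62.4 percentage points lower from compound 1 to compound 3 (beyond the scatter).

Compound 4 `COc1cc(Cl)cc(-c2nn(-c3cccc(NC(=O)c4cccc(C(F)(F)F)c4)c3)cc2-c2ccncc2)c1` differs from compound 3 in one place: 3-(trifluoromethyl)phenyl in place of (3-(trifluoromethyl)phenyl)amino on a carbonyl carbon. Compound 4 therefore carries its aryl directly on the carbonyl carbon, as compound 1 does, while compound 2 and compound 3 carry an amino group between aryl and carbonyl.

Among the compounds with values here, the steps that bear on this are a number 69.1 percentage points lower from compound 1 to compound 2 (beyond the scatter) and a number 62.4 percentage points lower from compound 1 to compound 3 (beyond the scatter), both large, both away from the direct aryl link. Reversing that link in compound 4 is expected to undo most of the drop, so a large rise in this assay is expected: a number 54.1 percentage points higher from compound 3 to compound 4 (beyond the scatter).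

Compound 4 is thus estimated at 58%, with a range from 28% to 85%.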

Compound 4, a percentage reported as activity, at one concentration (the size of the read-out at that concentration, not a potency): 69%
Compound 4: middle estimate off by 11 percentage points, on the low side, and the stated range covers the measured number.
By their numbers in this assay, from the lowest: compounds 2 and 3 (each within the scatter of the next); then compounds 1 and 4 (each within the scatter of the next).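

Within the data shown here, compound 4 separates two changes that came together in the earlier steps: with 3-(trifluoromethyl)phenyl kept, taking away only the amino group on the carbonyl carbon gives a number 65.1 percentage points higher from compound 3 to compound 4 (beyond the scatter) in this assay. Set against the chlorinated urea partner, the result is a number 71.8 percentage points higher from compound 2 to compound 4 (beyond the scatter), whereas 3-(trifluoromethyl)phenyl and 3,4-dichlorophenyl on the carbonyl carbon cannot be told apart, with a number 2.7 percentage points higher from compound 1 to compound 4 (within the scatter). Among these four compounds, the stronger effect therefore goes with the amino group rather than with the aryl substituents, and nothing available gives a reason for this.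

As far as these compounds go, it remains open whether the amide hydrogen of that amino group is what counts, which a methylated amino group or an oxygen atom in its place could test. Also open, from the compounds shown here alone, is whether the same step holds with a methoxy group or a nitrile on the aryl ring.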